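The source may report more compounds than this note shows. Statements on the series, on what has been measured and on what is new or still open speak of the compounds shown alone.

Working notes on the series. Of the compounds shown here, three sharing one core have been measured in an assay on isolated protein for binding affinity to 5-hydroxytryptamine receptor 6 (Homo sapiens); a higher number here means a weaker inhibitor, a lower number a stronger inhibitor. Compound 1 `O=S(=O)(Nc1ccc2nccc(N3CCNCC3)c2c1)c1cc(Cl)cc(Cl)c1` gives 25.1 nM. Compound 2 `Cc1sc2c(Cl)cccc2c1S(=O)(=O)Nc1ccc2nccc(N3CCNCC3)c2c1` gives 2 nM. Compound 3 `Cc1c(S(=O)(=O)Nc2ccc3nccc(N4C[C@@H](C)NC[C@@H]4C)c3c2)sc2ccc(Cl)cc12` gives 31.6 nM. Among these three numbers compound 3 stands highest; the nearest to it is compound 1, whose value lies within the usual scatter of that of compound 3, and the furthest is compound 2, whose value lies well below that of compound 3, beyond the scatter.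

Compound 4 `Cc1c(S(=O)(=O)Nc2ccc3nccc(N4C[C@@H](C)N[C@@H](C)C4)c3c2)sc2ccc(Cl)cc12` has not yet been measured. It differs from compound 3 in a single place: 3,5-dimethylpiperazin-1-yl in place of 2,5-dimethylpiperazin-1-yl on an aromatic carbon. The two have the same atoms, joined differently. Within the data shown here, no pair of measured compounds in the set differs by this change alone, so there is no measured step from which to read its size. The step of a 1.1-fold lower number from compound 3 to compound 4 (0.02 log units; within the scatter) is expected to be small, in either direction, and probably not beyond the scatter. On that basis compound 4 is expected to give about 30 nM in this assay, with a plausible range from 8 nM to 120 nM.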

Compound 4, inhibition constant: 5.01 nM
Compound 4: middle estimate off by 6.0-fold (0.78 log units), on the high side, and the stated range ends above it.
By their numbers in this assay, from the lowest: compound 2; then compound 4; then compounds 1 and 3 (each within the scatter of the next).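

In this assay, among these compounds, exchanging 2,5-dimethylpiperazin-1-yl for 3,5-dimethylpiperazin-1-yl on an aromatic carbon gives a 6.3-fold lower number from compound 3 to compound 4 (0.80 log units; beyond the scatter), the first step that can be read at this position. The two groups match in heavy atoms, ring type, hydrogen-bond donors and acceptors, and defined stereocentres, so this step shows that how the same atoms are joined in the ring at this position can alone move the number beyond the scatter, which compounds 1, 2 and 3 could not show because no two of them differ in one place only. No measurement here bears on the origin of this step.

This single pair leaves open whether a step of this size would also appear with the sulfonyl parts of compound 1 or compound 2, and how other stereoisomers of either dimethylpiperazine would compare. Among the compounds shown here, it also remains open how a piperazine with only one methyl group, such as 3-methylpiperazin-1-yl, or a seven-membered homopiperazine would read at the same position on the otherwise unchanged structure of compound 4.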